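A few compounds are considered here, and "the series" means these few. Any claim that something is new, unique, unknown or untested is made for them only; others in the source may bear on it.

Measured compounds in a functional assay on MCF7 cells (Homo sapiens) for antiproliferative activity, read by MTT assay, with a stated time of 48 h; on this read-out higher numbers stand for weaker inhibition and lower numbers for stronger inhibition:

Compound 1, `CCn1c(C(=O)NCCCN(C)C)ccc1C(CC)(CC)c1ccc(OCCC(O)(CC)CC)c(C)c1`, gives 3350 nM.
Compound 2, `C#CCCOC(=O)c1ccc(C(CC)(CC)c2ccc(OCCC(O)(CC)CC)c(C)c2)n1CC`, returns only the limit > 50000 nM.
Compound 3, `CCn1c(C(=O)Nc2cccc(C(F)(F)F)c2)ccc1C(CC)(CC)c1ccc(OCCC(O)(CC)CC)c(C)c1`, likewise returns only the limit > 50000 nM.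

Compound 3 therefore stands at the ceiling of this assay, a position it shares with compound 2, as the limit of > 50000 nM in this assay, at which 2 of the 3 values shown sit, shows; compound 1 alone gives a number. Compound 4, `CCC(C)C(CO)NC(=O)c1ccc(C(CC)(CC)c2ccc(OCCC(O)(CC)CC)c(C)c2)n1CC`, is reached from compound 3 by one change: 1-(hydroxymethyl)-2-methylbutyl in place of 3-(trifluoromethyl)phenyl on an amide-type nitrogen.

Going by the values given here, two measured steps bear on this. The step of an at least 14-fold higher number from compound 1 to compound 3 (1.17 log units; beyond the scatter) shows that exchanging the 3-(dimethylamino)propyl of compound 1 for the 3-(trifluoromethyl)phenyl costs a great deal, and the step of an at least 14-fold higher number from compound 1 to compound 2 (1.17 log units; beyond the scatter) shows a loss of the same size when the (3-(dimethylamino)propyl)amino is replaced altogether. Compound 4 brings back an alkyl chain with a hydrogen-bond donor and acceptor on the amide-type nitrogen, though without the dimethylamino of compound 1. A move back toward a measurable number is expected, and the estimated step is an at least 2.5-fold lower number from compound 3 to compound 4 (0.39 log units; beyond the scatter), its size uncertain because compound 3 sits at a limit. Compound 4 is thus expected to give roughly 20000 nM, within 5000 nM to 60000 nM.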

Compound 4, half-maximal inhibitory concentration: 29100 nM
The estimate for compound 4 lay 1.5-fold (0.16 log units) below the measured number, and the stated range covers the measured number.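

Compound 2 and compound 3 remain limits in this assay, not numbers: the limit of > 50000 nM in this assay, at which 2 of the 4 values shown sit. From the compounds shown here alone, on the amide-type nitrogen, 1-(hydroxymethyl)-2-methylbutyl gives a measurable number where 3-(trifluoromethyl)phenyl gave only a limit, yet an at least 1.7-fold lower number from compound 3 to compound 4 (0.23 log units; that floor lies within the scatter) and an at least 1.7-fold lower number from compound 2 to compound 4 (0.23 log units; that floor lies within the scatter) are only floors that lie within the scatter, so the true size of the gain stays unknown. The comparison with the one other measured amide is firmer, an 8.7-fold higher number from compound 1 to compound 4 (0.94 log units; beyond the scatter), so 1-(hydroxymethyl)-2-methylbutyl does not match 3-(dimethylamino)propyl at this place.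

The compounds shown leave open whether that gap follows the dimethylamino group itself or the chain that carries it. A primary amine or a morpholine in place of the dimethylamino group, or a plain alkyl chain on the same nitrogen, would bear on this.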